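Pentyl on selenium in two quinazoline-type cores

The source may hold more compounds than are shown below. What is called first, only, known or untested is meant among the compounds shown, and "the series" means these compounds.

Compound 2 `[SeH]c1nc(NCc2ccccc2)c2ccccc2n1` and compound 1 `CCCCC[Se]c1nc(NCc2ccccc2)c2ccccc2n1` share a core and differ only by pentyl in place of hydrogen on a selenium. In a functional assay on MCF7 cells (Homo sapiens) for cytotoxicity, read by MTT assay, with a stated time of 72 h (a lower number here means a stronger inhibitor of growth, a higher number a weaker inhibitor of growth), compound 1 gives 47100 nM. For compound 2 this assay reports only a limit, > 100000 nM. The step of an at least 2.1-fold lower number from compound 2 to compound 1 (0.32 log units; beyond the scatter) is therefore known only as a lower bound, given (the limit of > 100000 nM in this assay, at which 2 of the 3 values shown sit). Compound 3 `Nc1nc([SeH])nc2ncccc12` has a different core; the difference between the two cores is not broken down here. For compound 3 this assay again reports only a limit, > 100000 nM. Compound 4 `CCCCC[Se]c1nc(N)c2cccnc2n1` differs from compound 3 by pentyl in place of hydrogen on a selenium, the same change as before, at the same kind of place. Because compound 1 reached 47100 nM after that change, compound 4 is expected to show a step of about an at least 1.6-fold lower number from compound 3 to compound 4 (0.22 log units; that floor lies within the scatter), and its value in this assay is estimated at 60000 nM, between 20000 nM and 150000 nM.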

Compound 4, concentration for total growth inhibition: 53800 nM
For compound 4 the middle estimate is 1.1-fold (0.05 log units) above the measured one; low and high end bracket the measured number.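

In this assay, pentyl in place of hydrogen on a selenium carries over to the core of compound 3 as an at least 1.8-fold lower number from compound 3 to compound 4 (0.26 log units; that floor lies within the scatter), which fits the earlier result on the core of compound 2 but does not by itself establish a step beyond the scatter. The two steps agree in direction, yet their sizes cannot be set against each other: the same change on two cores in this assay, an at least 2.1-fold lower number (0.32 log units; beyond the scatter) from compound 2 to compound 1 and an at least 1.8-fold lower number (0.26 log units; that floor lies within the scatter) from compound 3 to compound 4; the limit leaves it open whether they differ. Both starting compounds are known only as limits, so neither full step size can be read: the limit of > 100000 nM in this assay, at which 2 of the 4 values shown sit.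

The compounds shown leave open whether a shorter chain such as ethyl or a longer chain such as octyl on the selenium would give a similar step. They also leave open how a benzylamine group would behave on the core of compound 4.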